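Working notes: from compound 3 to compound 4

This account rests on a few compounds, and the source may have more. Where it says the series, first, only, none or still open, it means among the compounds named here.

Compound 3 `C[C@H](Nc1ncnc2[nH]cnc12)c1nn(-c2cccc(F)c2)c2cc(F)ccc12` is measured in a functional assay on Hep 3B2 cells (Homo sapiens) for inhibition, read by sulforhodamine B assay, with a stated time of 72 h, tested at 10 uM (on this read-out higher numbers stand for more inhibition at the one concentration tested (going by the name of the read-out) and lower numbers for less inhibition), and gives 28%. That is the highest of the three numbers in hand. Compound 1 `C[C@H](Nc1ncnc2[nH]cnc12)c1nn(-c2cccnc2)c2ccc(F)cc12` gives in this assay 13%, and compound 2 `Cc1ccc2c(c1)c([C@H](C)Nc1ncnc3[nH]cnc13)nn2-c1cccnc1` gives 8%; both sit beyond the scatter below compound 3. Among the compounds with values here, the one single-point step measured so far is a number 5 percentage points lower from compound 1 to compound 2 (within the scatter), which concerns a substituent on an aromatic carbon and does not touch the group that changes here.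

Compound 4 `C[C@H](Nc1ncnc2[nH]cnc12)c1nn(-c2cccnc2)c2cc(F)ccc12` is not yet measured. It differs from compound 3 in one place: pyridin-3-yl in place of 3-fluorophenyl on an aromatic nitrogen. The step from compound 1 to compound 2 tells nothing about an exchange on the aromatic nitrogen. Within the data shown here, compound 1 and compound 3 differ in two places, one of them this same exchange, so no step is counted between them; compound 1 at 13% against compound 3 at 28% only shows that the member bearing pyridin-3-yl lies lower. On that thin basis a downward step is expected for compound 4 in this assay, estimated as a number 10 percentage points lower from compound 3 to compound 4 (within the scatter), which may or may not exceed the scatter. The value of compound 4 is expected to be 18%, with a range from 5% to 33%.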

Compound 4, a percentage reported as inhibition, at one concentration (the size of the read-out at that concentration, not a potency): 20%
Estimate against measurement, compound 4: 2 percentage points below, within the range that was stated.
By their numbers in this assay, from the lowest: compounds 2, 1, 4 and 3 (each within the scatter of the next, the first and the last beyond it).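

In this assay, within the data shown here, the exchange on the aromatic nitrogen can now be read in one place for the first time, and it gives a number 8 percentage points lower from compound 3 to compound 4 (within the scatter). Among these compounds, the only earlier step concerned a substituent on an aromatic carbon, so this is the first sign that pyridin-3-yl, with its hydrogen-bond acceptor and without the fluorine of 3-fluorophenyl, can stand at this position with a step that stays within the scatter; this single pair cannot show a real effect of the exchange in either direction, and it rests on one fluorinated core only. Nothing at hand gives a measured property or other evidence that bears on this step.

The compounds shown carry only two six-membered aromatic rings on this nitrogen, so it remains open whether a saturated ring amine such as piperidin-4-yl, a benzoic acid group or a longer alkyl chain there would give a step beyond the scatter. Also open, going by these compounds, is whether the same exchange would give a step of similar size on the core of compound 1 or compound 2, where a matching 3-fluorophenyl partner would be needed.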